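The compounds below may be only part of what the source reports. "The series", "measured", "known", "first", "only" and "open" are said of these compounds alone.

Working notes on the series. Compound 1 `Cc1cc(O)c(C(=O)/C=C/c2ccc(OCc3ccccc3)cc2)c(-c2ccccc2)c1C(=O)/C=C/c1ccc(OCc2ccccc2)cc1` gives 30000 nM in an ADME assay on HEK293 cells (Homo sapiens) for cytotoxicity, read by MTT assay, with a stated time of 24 h; a lower number here means a stronger inhibitor, a higher number a weaker inhibitor. Compound 2 `Cc1cc(O)c(C(=O)/C=C/c2ccc(OCc3ccccc3)cc2)c(-c2ccc(Br)cc2)c1C(=O)/C=C/c1ccc(OCc2ccccc2)cc1` carries the change bromo in place of hydrogen on an aromatic carbon and gives 25000 nM in this assay; the step of a 1.2-fold lower number from compound 1 to compound 2 (0.08 log units; within the scatter) is small. Compound 3 `Cc1cc(O)c(C(=O)/C=C/c2ccc(Br)cc2)c(-c2ccccc2)c1C(=O)/C=C/c1ccc(Br)cc1` gives 10000 nM in this assay, the lowest number of the three measured, and its distance from compound 2 and from compound 1 lies beyond the scatter in both cases. How the core of compound 3 differs from the core of compound 1 is not broken down here.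

Compound 4 `Cc1cc(O)c(C(=O)/C=C/c2ccc(Br)cc2)c(-c2ccc(Br)cc2)c1C(=O)/C=C/c1ccc(Br)cc1` is not yet measured. It differs from compound 3 by bromo in place of hydrogen on an aromatic carbon, at a place described in the same words as for the change from compound 1 to compound 2, so the two changes are the same change made on two different cores. Because the earlier step of a 1.2-fold lower number from compound 1 to compound 2 (0.08 log units; within the scatter) stayed within the scatter, the step from compound 3 to compound 4 is expected to be of similar size, a 1.2-fold lower number from compound 3 to compound 4 (0.07 log units; within the scatter). Compound 4 is accordingly expected to give about 8500 nM in this assay, between 4000 nM and 18000 nM.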

Compound 4, half-maximal inhibitory concentration: 30000 nM
Compound 4: middle estimate off by 3.5-fold (0.55 log units), on the low side; the whole stated range lies below it.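

The change from phenyl to 4-bromophenyl gives a 3.0-fold higher number from compound 3 to compound 4 (0.48 log units; beyond the scatter) in this assay. The same change therefore does not carry over unchanged from one core to the other, as the two steps differ in size and direction: the same change on two cores in this assay, a 1.2-fold lower number (0.08 log units; within the scatter) from compound 1 to compound 2 and a 3.0-fold higher number (0.48 log units; beyond the scatter) from compound 3 to compound 4, 3.6-fold (0.56 log units) apart, beyond the scatter of two such steps This rests on a single pair of steps and shows only that the outcome of this change depends on the core in these two cases; it does not show what in the cores is responsible, or how the change would behave on any further core.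

Open, going by these compounds, is whether the dependence on the core is specific to bromo, or whether an amine or a carboxylic acid in the same place on the phenyl ring would also give steps that differ between the core of compound 1 and the core of compound 3. Also open, on these data alone, is how the step would behave on a core with a methoxy group or a longer chain in place of the groups that separate these two cores.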